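Saturating the long chain at the assay limit

The source may report more compounds than this note shows. Statements on the series, on what has been measured and on what is new or still open speak of the compounds shown alone.

Compound 1 `CCCC/C=C\CCCCCCCCCc1cc(=O)c2c(O)c(C)c(O)c(C)c2o1` and compound 2 `CCCC/C=C\CCCCCCCCCc1cc(=O)c2c(O)c(C)c(OCOC)c(C)c2o1` share a core and a long unsaturated chain. In a functional assay on MCF7 cells (Homo sapiens) for antiproliferative activity, read by MTT assay (on this read-out lower numbers stand for stronger inhibition and higher numbers for weaker inhibition), compound 1 gives > 67200 nM, which is a limit and not a number. Compound 2 gives > 67200 nM, again a limit and not a number. Compound 2 therefore has no exact position on the scale, and the whole picture so far is the limit of > 67200 nM in this assay, at which 2 of the 2 values shown sit.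

Compound 3 `CCCCCCCCCCCCCCCc1cc(=O)c2c(O)c(C)c(OCOC)c(C)c2o1` keeps the methoxymethyl group of compound 2 but changes the chain: hexyl in place of hex-1-en-1-yl on a saturated chain carbon, nine bonds along the chain from an aromatic carbon. The double bond in the chain is gone, and the core stays the same.

Within the data shown here, only one measured step is available, a step that the two limits leave unreadable from compound 1 to compound 2. It has no readable size and does not involve the chain, so it offers no guide to this change. With compound 2 resting on its limit of > 67200 nM, no clear shift in either direction is expected in this assay. The expected change is a step that the limit leaves unreadable from compound 2 to compound 3, and it is no more than a cautious estimate. For compound 3 the estimated value is 70000 nM, with an expected range from 30000 nM to 120000 nM.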

Compound 3, half-maximal inhibitory concentration: > 67200 nM
Compound 3 ended at the assay's limit; the forecaster's own chance of this, stated with the estimate: 75%; the middle value is on the limit's open side.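

Compound 3 also gives a limit and not a number, so the change from hex-1-en-1-yl to hexyl cannot be read as a step between compound 2 and compound 3. The compounds shown leave open how strongly any of them acts in this assay, and whether this change in the chain matters there: the limit of > 67200 nM in this assay, at which 3 of the 3 values shown sit.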